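Replacing the pentafluorophenyl group of compound 2

The compounds below may be only part of what the source reports. "The series", "measured", "known", "first", "only" and "open" are said of these compounds alone.

Compound 1 `Cc1ccc(CS/C(=C/c2ccc(O)cc2)C(=O)c2ccc(Cl)cc2)cc1` gives 10000 nM
Compound 2 `O=C(/C(=C\c1ccc(O)c([N+](=O)[O-])c1)SCc1ccc(Br)cc1)c1c(F)c(F)c(F)c(F)c1F` gives 10000 nM
Compound 3 `Cc1ccc(/C=C(/SCc2ccc(Cl)cc2Cl)C(=O)c2ccc(Cl)cc2)s1` gives 50000 nM

All three compounds were tested in a functional assay on DU-145 cells (Homo sapiens) for inhibition, read by trypan blue exclusion, with a stated time of 96 h; on this read-out lower numbers stand for stronger inhibition of growth and higher numbers for weaker inhibition of growth. Compound 2 stands level with compound 1, and together they hold the lowest number of the three. Compound 3 stands at 50000 nM. Its gap to the other two lies beyond the scatter, on the higher side.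

Compound 4 `O=C(O)c1ccc(C(=O)/C(=C\c2ccc(O)c([N+](=O)[O-])c2)SCc2ccc(Br)cc2)cc1` has not yet been measured. It differs from compound 2 in one place: 4-carboxyphenyl in place of 2,3,4,5,6-pentafluorophenyl on a carbonyl carbon. There, 4-carboxyphenyl stands in place of 2,3,4,5,6-pentafluorophenyl on a carbonyl carbon.

Among the measured compounds shown here, no measured pair in this small set differs in only one place, so the data show no direct precedent for this change. For the measured compounds named here, the only guide is the spread of the measured values, from compound 2 at 10000 nM to compound 3 at 50000 nM. Within that spread, a modest step towards a higher number, meaning weaker inhibition of growth, is expected, although a result within the scatter would be no surprise. The expected size of the change is estimated as a 2.0-fold higher number from compound 2 to compound 4 (0.30 log units; within the scatter). In this assay the estimate for compound 4 is 20000 nM, with an expected range of 6000 nM to 60000 nM.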

Compound 4, concentration for 50% growth inhibition: 50000 nM
Compound 4: the middle estimate sits 2.5-fold (0.40 log units) below what was measured; measured number inside the range.
By their numbers in this assay, from the lowest: compounds 1 and 2 (each within the scatter of the next); then compounds 3 and 4 (each within the scatter of the next).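

In this assay, among the compounds shown here, placing 4-carboxyphenyl in place of 2,3,4,5,6-pentafluorophenyl on the carbonyl carbon gives a 5.0-fold higher number from compound 2 to compound 4 (0.70 log units; beyond the scatter), and this is the first direct reading of a single change in this set. It shows that the group at this position is not indifferent: with the rest of compound 2 held fixed, this one exchange moves the number beyond the scatter, towards weaker inhibition of growth. Nothing available explains the shift or assigns it to either the departing fluorine atoms or the entering carboxyl group.

The compounds shown leave open whether the step belongs to the carboxyl group itself or to the loss of the pentafluorophenyl group, a question that an unsubstituted phenyl, a 4-(methoxycarbonyl)phenyl or a 4-aminophenyl group at the same place could help to separate. They also leave open whether the same exchange would move the number in a similar way on the other substitution patterns seen in compound 1 and compound 3, since this single step comes from the background of compound 2 alone.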